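Trifluoromethyl for iodo on the aryl of compound 2

The compounds below may be only part of what the source reports. "The series", "measured", "known", "first", "only" and "open" are said of these compounds alone.

Compound 1 `Cc1ccccc1-n1nc(C)c2c1NC(=O)[C@H](C)S[C@@H]2c1ccc(-c2ccoc2)cc1` gives 3500 nM in an assay on isolated protein for agonist activity at Bile acid receptor (Homo sapiens), read by AlphaScreen, with a stated time of 30 min; on this read-out higher numbers stand for an effect only at larger amounts of compound and lower numbers for an effect already at smaller amounts. Compound 2 `Cc1nn(-c2ccccc2I)c2c1C(c1ccc(Oc3ccccc3)cc1)SC(C)C(=O)N2` gives 1300 nM in this assay, the lower of the two numbers, with compound 1 standing higher by a margin beyond the scatter. Compound 3 `Cc1nn(-c2ccccc2C(F)(F)F)c2c1C(c1ccc(Oc3ccccc3)cc1)SC(C)C(=O)N2` differs from compound 2 in one place: trifluoromethyl in place of iodo on an aromatic carbon. Within the data shown here, no measured pair in this set shows a change of this kind, so the step from compound 2 to compound 3 is expected to stay within the scatter, a 1.2-fold higher number from compound 2 to compound 3 (0.06 log units; within the scatter). For compound 3 the value in this assay is estimated at 1500 nM, within 500 nM to 5000 nM.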

Compound 3, half-maximal effective concentration: 2000 nM
The estimate for compound 3 lay 1.3-fold (0.12 log units) below the measured number, and the stated range covers the measured number.
By their numbers in this assay, from the lowest: compounds 2, 3 and 1 (each within the scatter of the next, the first and the last beyond it).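

In this assay, among these compounds, the change from 2-iodophenyl to 2-(trifluoromethyl)phenyl gives a 1.5-fold higher number from compound 2 to compound 3 (0.19 log units; within the scatter) and is the first single-place comparison. At this place, on an aromatic carbon ortho to a large group, the read-out does not separate iodo from trifluoromethyl, although the heavy-atom count differs. No measurement here bears on the reason for this result.

Going by these compounds, whether an amine, a carboxylic acid or a longer chain at this place would move the number beyond the scatter remains open. Also open, on these data alone, is whether the same exchange holds with the other substituents of compound 1 on the shared core.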